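The source may hold more compounds than are shown below. What is called first, only, known or untested is meant among the compounds shown, and "the series" means these compounds.

Working notes on the series. Compound 1 `O=C(/C=C/c1ccc(Cl)c([N+](=O)[O-])c1)/C=C/c1ccccc1Oc1ncnc2ccc(Cl)cc12` is the reference point: in a functional assay on PC-3 cells (Homo sapiens) for inhibition, read by MTT assay, with a stated time of 72 h, tested at 10 uM (a lower number here means less inhibition of growth, a higher number more inhibition of growth at the concentration tested), compound 1 gives 62.5%. For the measured compounds named here, compound 3 `O=C(/C=C/c1ccc(Cl)c(Cl)c1)/C=C/c1ccccc1Oc1ncnc2ccc(Cl)cc12` carries the change (chloro in place of nitro on an aromatic carbon), and in this assay compound 3 gives 42.2%; the step of a number 20.3 percentage points lower from compound 1 to compound 3 (beyond the scatter) is the only measured instance of this change so far. Compound 2 `O=C(/C=C/c1ccc(Oc2ncnc3ccc(Cl)cc23)cc1)/C=C/c1ccc(Cl)c([N+](=O)[O-])c1` has the same atoms as compound 1 joined differently; the difference between the two cores is not broken down here. In this assay compound 2 gives 56.3%, and the values of compound 1 and compound 2 sit within the scatter of each other, so no order between them is read.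

Compound 4 `O=C(/C=C/c1ccc(Oc2ncnc3ccc(Cl)cc23)cc1)/C=C/c1ccc(Cl)c(Cl)c1` is the counterpart of compound 3 on the core of compound 2, with the difference (chloro in place of nitro on an aromatic carbon). The surroundings of the exchanged group are described in the same words for both pairs, so this is the same change. On the core of compound 1 it cost a number 20.3 percentage points lower from compound 1 to compound 3 (beyond the scatter). Starting from compound 2, a step of similar size is expected, that is a number 19.3 percentage points lower from compound 2 to compound 4 (beyond the scatter), because compound 1 lost a number 20.3 percentage points lower from compound 1 to compound 3 (beyond the scatter) on the one measured occasion. Accordingly compound 4 is estimated at 37% in this assay, with a plausible span from 24% to 50%, the width reflecting that the step rests on a single measured pair.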

Compound 4, percent growth inhibition at one concentration: 33.5%
Beside the measured number, compound 4's estimate is 3.5 percentage points above it, and the stated range covers the measured number.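

In this assay the exchange of nitro for chloro on the core of compound 2 gives a number 22.8 percentage points lower from compound 2 to compound 4 (beyond the scatter). Set beside the step on the core of compound 1, the change carries over between these two cores with its size kept: the same change on two cores in this assay, a number 20.3 percentage points lower (beyond the scatter) from compound 1 to compound 3 and a number 22.8 percentage points lower (beyond the scatter) from compound 2 to compound 4, 2.5 percentage points apart, within the scatter of two such steps. For the compounds shown here, this rests on only two pairs, both with the same exchange, 4-chloro-3-nitrophenyl to 3,4-dichlorophenyl, in one cell line at one concentration, so it does not show that the step would hold on any further core or in any other read-out.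

The compounds shown hold only nitro and chloro at this place on the aromatic ring, so what an amine, a nitrile or a carboxylic acid there would give stays open. Also open, as far as these compounds go, is whether a plain hydrogen at the same place would fall nearer the nitro compounds or the chloro compounds on either core.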